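Does Losing One Methyl Change Cell Toxicity?

The source may report more compounds than this note shows. Statements on the series, on what has been measured and on what is new or still open speak of the compounds shown alone.

In a toxicity assay on MCF7 cells (Homo sapiens) for cytotoxicity, read by MTT assay, with a stated time of 3 h (on this read-out lower numbers stand for stronger inhibition and higher numbers for weaker inhibition), compound 1 `COc1ccc2c(c1)CCc1c(-c3ccccc3)c3n(c1-2)[B-](F)(F)[N+]1=C(c2ccc(C)cc2)C(I)=C(c2ccccc2)C1=N3` gives > 50000 nM, which is a limit of the assay and not a number. Compound 2 `COc1ccc2c(c1)CCc1c(-c3ccccc3)c3n(c1-2)[B-](F)(F)[N+]1=C(c2ccc(C)s2)C(I)=C(c2ccccc2)C1=N3`, with 5-methylthiophen-2-yl in place of 4-methylphenyl, gives > 50000 nM in this assay, and this too is only a limit. Both compounds therefore stand at the same boundary (the limit of > 50000 nM in this assay, at which 2 of the 2 values shown sit), and no measured number exists yet in this series.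

Compound 3 `COc1ccc2c(c1)CCc1c(-c3ccccc3)c3n(c1-2)[B-](F)(F)[N+]1=C(c2cccs2)C(I)=C(c2ccccc2)C1=N3` comes from compound 2 by one small edit: hydrogen in place of methyl on an aromatic carbon. In words, 5-methylthiophen-2-yl becomes thiophen-2-yl. Among the compounds with values here, only one measured step bears on this edit, the one at the same group, a step that the two limits leave unreadable from compound 1 to compound 2. It has no size that can be carried over, yet exchanging the whole group left both compounds at the limit. Removing one methyl is thus expected to change little, with no shift in either direction beyond the usual scatter. The expected step is a number no higher from compound 2 to compound 3 (the limit leaves the size open). For compound 3 the estimated value is 50000 nM, with an expected range from 25000 nM to 100000 nM.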

Compound 3, half-maximal inhibitory concentration: > 50000 nM
Compound 3: a limit, no number; the forecaster's own chance of this, stated with the estimate: 85%; the middle value sits exactly at the limit.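

In this assay compound 3 gives > 50000 nM as a limit of the assay and not a number. Within the data shown here, no step among compound 1, compound 2 and compound 3 can be read, and all three stay at one boundary: the limit of > 50000 nM in this assay, at which 3 of the 3 values shown sit. The compounds shown leave open how strongly any of them acts on these cells, and whether removing the methyl matters at all.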